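Swapping the Side Group in a Thromboxane Synthase Inhibitor

The source may report more compounds than this note shows. Statements on the series, on what has been measured and on what is new or still open speak of the compounds shown alone.

Compound 3 `CC(C)(Oc1ccccc1F)C1OCC(C/C=C\CCC(=O)O)C(c2cccnc2)O1` gives 45 nM in an assay for inhibition of Thromboxane-A synthase (Homo sapiens), using microsomes; a higher number here means a weaker inhibitor, a lower number a stronger inhibitor. Among the three measured compounds it stands second highest, though its gaps to compound 1 `O=C(O)CC/C=C\CC1COC(c2ccc(C(F)(F)F)cc2)OC1c1cccnc1` at 44 nM and to compound 2 `O=C(O)CC/C=C\CC1COC(c2cccs2)OC1c1cccnc1` at 71 nM are both within the scatter. Compound 4 `CC(C)(Cc1ccc(F)cc1C#N)C1OCC(C/C=C\CCC(=O)O)C(c2cccnc2)O1` differs from compound 3 by a group of 10 heavy atoms (8 carbon, 1 nitrogen, 1 fluorine; one six-membered aromatic ring of carbon only) in place of a group of 8 heavy atoms (6 carbon, 1 oxygen, 1 fluorine; one six-membered aromatic ring of carbon only), on a saturated chain carbon bound to two saturated chain carbons and a saturated ring carbon. Among the measured compounds shown here, only one measured step exists, a 1.6-fold higher number from compound 1 to compound 2 (0.21 log units; within the scatter), and it swaps a group on a saturated ring carbon rather than on the saturated chain carbon changed here, so it bears only loosely. That step stayed within the scatter, and all three values sit close together, so no step beyond the scatter is expected for a 1.1-fold higher number from compound 3 to compound 4 (0.05 log units; within the scatter) in this assay. Compound 4 is therefore estimated at 50 nM, within 20 nM to 130 nM.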

Compound 4, half-maximal inhibitory concentration: < 10 nM
Compound 4: a limit, no number (the forecaster's own chance of this, stated with the estimate: 3%); at least 5.0-fold (0.69 log units) between middle value and limit.
By their numbers in this assay, from the lowest: compounds 1, 3 and 2 (each within the scatter of the next). At a limit, below all of these: compound 4.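

Replacing 2-fluorophenoxy with the group of 10 heavy atoms, on the saturated chain carbon, gives an at least 4.5-fold lower number from compound 3 to compound 4 (0.65 log units; beyond the scatter) in this assay. The only earlier step, on a saturated ring carbon, stayed within the scatter, so this chain carbon is the first place shown where a swap moves the number beyond it. Compound 4 gives a limit, not a number: the limit of < 10 nM in this assay, at which 1 of the 4 values shown sits.

The compounds shown leave open which part of the entering group, such as its nitrile, accounts for the step. Going by these compounds, what an amine at this chain carbon would give also stays open.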